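The source may hold more compounds than are shown below. What is called first, only, known or untested is meant among the compounds shown, and "the series" means these compounds.

In an assay on isolated protein (Cavia porcellus) with Sigma non-opioid intracellular receptor 1 (Homo sapiens) as the target, read by radioligand binding (on this read-out higher numbers stand for weaker inhibition and lower numbers for stronger inhibition), compound 3 `O=c1cc(-c2ccccc2Cl)oc2ccc(OCCCCCCN3CCC(O)CC3)cc12` gives 29 nM, the lowest of the three numbers seen so far. Compound 1 `CN(C)CCCCCCOc1ccc2oc(-c3ccccc3)cc(=O)c2c1` gives 335 nM and compound 2 `O=c1cc(-c2ccccc2)oc2ccc(OCCCCCCN3CCNC(CCO)C3)cc12` gives 94 nM. Within the data shown here, the only step between compounds that differ in a single place, a 3.6-fold lower number from compound 1 to compound 2 (0.55 log units; beyond the scatter), concerns the amine part of the chain. Compound 4 `O=c1cc(C2CCCC2)oc2ccc(OCCCCCCN3CCC(O)CC3)cc12` differs from compound 3 in a different way: cyclopentyl in place of 2-chlorophenyl on an aromatic carbon. Among the measured compounds shown here, no measured step touches this group, and compounds 2 and 3 differ in two places at once, so the available data give no direct guide. For the measured compounds named here, with no precedent, the expectation for compound 4 is a change of only modest size, a 2.1-fold higher number from compound 3 to compound 4 (0.32 log units; beyond the scatter), estimated at 60 nM with a range from 15 nM to 250 nM.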

Compound 4, half-maximal inhibitory concentration: 55 nM
Compound 4: the middle estimate sits 1.1-fold (0.04 log units) above what was measured; low and high end bracket the measured number.
By their numbers in this assay, from the lowest: compounds 3, 4 and 2 (each within the scatter of the next, the first and the last beyond it); then compound 1.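

Putting cyclopentyl in place of 2-chlorophenyl on the aromatic carbon next to the ring oxygen gives a 1.9-fold higher number from compound 3 to compound 4 (0.28 log units; within the scatter) in this assay, a step within the scatter. For this pair, then, an aromatic ring at this position is not needed to keep the number in this range, and neither is the chlorine. Nothing measured here explains this result. Going by these compounds, whether a smaller methyl or a larger cyclohexyl at this position would read alike stays open. So does whether the same swap behaves this way with dimethylamino as the amine on the chain.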